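The compounds below may be only part of what the source reports. "The series", "measured", "known", "first", "only" and "open" are said of these compounds alone.

Measured so far:
- compound 1, `CC(C(=O)NCc1ccc(C(F)(F)F)cc1N1CCCC1)c1ccc(NS(C)(=O)=O)c(F)c1`, with 2.3 nM in an assay on CHO cells for antagonist activity at transient receptor potential cation channel subfamily V member 1 (Homo sapiens), read by FLIPR; a higher number here means a weaker inhibitor, a lower number a stronger inhibitor
- compound 2, `CC(C(=O)NCc1ccc(C(F)(F)F)cc1N1CCC(C)(C)CC1)c1ccc(NS(C)(=O)=O)c(F)c1`, with 1.3 nM
- compound 3, `CC(C)CCOc1cc(C(F)(F)F)ccc1CNC(=O)C(C)c1ccc(NS(C)(=O)=O)c(F)c1`, with 0.5 nM

Compound 1 stands highest of the three numbers, which here means it is the weakest inhibitor of the three. Its nearest neighbour is compound 2, reached by a 1.8-fold lower number from compound 1 to compound 2 (0.25 log units; within the scatter). Its furthest is compound 3, reached by a 4.6-fold lower number from compound 1 to compound 3 (0.66 log units; beyond the scatter). The third pair shows a 2.6-fold lower number from compound 2 to compound 3 (0.41 log units; beyond the scatter).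

Compound 4, `CC(C(=O)NCc1ccc(C(F)(F)F)cc1SCc1ccco1)c1ccc(NS(C)(=O)=O)c(F)c1`, has not yet been measured. It differs from compound 1 at a single place:

((furan-2-yl)methyl)sulfanyl in place of pyrrolidin-1-yl on an aromatic carbon

Both measured steps that swap out the pyrrolidin-1-yl group at this position bear on the question. One stayed within the scatter, the other gave a modest drop in the number, and neither went upward. Neither step, however, brought in a sulfur atom or an aromatic ring, so they guide the expectation only loosely. A small to modest lowering of the number, or no step beyond the scatter, seems the likeliest outcome for compound 4.

Compound 4 is therefore estimated at 1.5 nM, with a range from 0.4 nM to 6 nM. That estimate would mean a 1.5-fold lower number from compound 1 to compound 4 (0.19 log units; within the scatter).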

Compound 4, inhibition constant: 3.2 nM
Compound 4: the middle estimate sits 2.1-fold (0.33 log units) below what was measured, and the stated range covers the measured number.
By their numbers in this assay, from the lowest: compound 3; then compounds 2, 1 and 4 (each within the scatter of the next, the first and the last beyond it).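

In this assay, the position ortho to a large group accepts ((furan-2-yl)methyl)sulfanyl, which brings in a sulfur atom and a five-membered aromatic ring, in place of pyrrolidin-1-yl without a change beyond the scatter (a 1.4-fold higher number from compound 1 to compound 4 (0.14 log units; within the scatter)). The replacement does, however, fall behind the other two groups tried here, both by steps beyond the scatter: isopentyloxy (a 6.4-fold higher number from compound 3 to compound 4 (0.81 log units; beyond the scatter)) and 4,4-dimethylpiperidin-1-yl (a 2.5-fold higher number from compound 2 to compound 4 (0.39 log units; beyond the scatter)). So the position does not treat all larger groups alike, and no measurement offered here explains the differences among them.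

In compound 4 the sulfur atom and the furan ring entered together, so these compounds cannot show what each contributes to the result. A (furan-2-yl)methoxy group, with oxygen in place of the sulfur, would separate the sulfur from the ring, while an isopentylsulfanyl group, with sulfur in place of the oxygen of compound 3, would test the sulfur link on the chain that gave the lowest number here.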